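The source may hold more compounds than are shown below. What is called first, only, known or untested is meant among the compounds shown, and "the series" means these compounds.

Compound 1 `O=[N+]([O-])c1ccc(O)c(/C=N/Nc2nc3ccccc3s2)c1`: in a functional assay on HL-60 cells (Homo sapiens) for cytotoxicity, read by MTT assay, with a stated time of 72 h (a higher number here means a weaker inhibitor, a lower number a stronger inhibitor), compound 1 gives 1650 nM.
Compound 2 `COc1cc(/C=N/Nc2nc3ccccc3s2)ccc1O`: in this assay compound 2 gives only a limit of the assay, > 16700 nM.
Compound 3 `Clc1ccc(/C=N/Nc2nc3ccccc3s2)cc1`: in this assay compound 3 gives only a limit of the assay, > 17300 nM.

Compound 3 thus sits at the limit of > 17300 nM in this assay, at which 1 of the 3 values shown sits, so no number is known for it, and compound 2 likewise sits at the limit of > 16700 nM in this assay, at which 1 of the 3 values shown sits; only compound 1 gives a real number. Compound 4 `CN(C)c1ccc(/C=N/Nc2nc3ccccc3s2)cc1` differs from compound 3 by dimethylamino in place of chloro on an aromatic carbon. Among the measured compounds shown here, no measured step between two compounds exists here, so the size of this change cannot be read from any neighbour. The step from compound 3 to compound 4 is expected to be an at least 1.1-fold lower number from compound 3 to compound 4 (0.06 log units; that floor lies within the scatter), nothing beyond the usual scatter. Compound 4 is therefore estimated at 15000 nM, within 3000 nM to 60000 nM.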

Compound 4, half-maximal inhibitory concentration: > 16800 nM
Compound 4 gave a limit, no number; the forecaster's own chance of this, stated with the estimate: 60%; middle value at least 1.1-fold (0.04 log units) from the limit.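

Among the compounds shown here, compound 3 and compound 4 both give only limits in this assay, and no step between them can be read. From the compounds shown here alone, what dimethylamino in place of chloro on an aromatic carbon does to the value remains open.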